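Urotensin-2 receptor series: amide substituent step to furan

The source may report more compounds than this note shows. Statements on the series, on what has been measured and on what is new or still open speak of the compounds shown alone.

Compound 2 `CN(C)CCCOc1ccc(CN2CC[C@H](NC(=O)c3ccc(C(F)(F)F)cc3)C2)cc1` carries a 4-(trifluoromethyl)phenyl group on the carbonyl carbon of the shared core. In an assay on HEK293 cells for binding affinity to Urotensin-2 receptor (Homo sapiens), read by radioligand binding (a lower number here means a stronger inhibitor, a higher number a weaker inhibitor), compound 2 gives only a limit, < 10000 nM, and no number. For the measured compounds named here, the one measured neighbour, compound 1 `CN(C)CCCOc1ccc(CN2CC[C@H](NC(=O)c3cc(Cl)cc(Cl)c3)C2)cc1`, gives 2000 nM in this assay. Going by the values given here, the only measured step, a step that the limit leaves unreadable from compound 1 to compound 2, is therefore unreadable, as the limit of < 10000 nM in this assay, at which 1 of the 2 values shown sits, shows. Compound 3 `CN(C)CCCOc1ccc(CN2CC[C@H](NC(=O)c3ccco3)C2)cc1` is obtained from compound 2 by the change (furan-2-yl in place of 4-(trifluoromethyl)phenyl on a carbonyl carbon). Among the compounds with values here, no measured step in this assay touches the furan-2-yl group, so nothing recorded here gives a size or direction for this change beyond what compound 2 itself shows. Since compound 2 stands at a limit, the step to compound 3 cannot be anchored to a number at either end. Compound 3 is expected to lie around 10000 nM, within a range from 2000 nM to 50000 nM, and the expected step is a number no lower from compound 2 to compound 3 (the limit leaves the size open), with a substantial chance that this assay again reports only a limit for compound 3.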

Compound 3, inhibition constant: < 10000 nM
Compound 3 ended at the assay's limit (the forecaster's own chance of this, stated with the estimate: 60%); the middle value sits exactly at the limit.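

No new step can be read in this assay: compound 2 and compound 3 are both reported only as limits, which leaves the steps among compound 1, compound 2 and compound 3 without a size: the limit of < 10000 nM in this assay, at which 2 of the 3 values shown sit.

Still open, from the compounds shown here alone, is how furan-2-yl, 4-(trifluoromethyl)phenyl and 3,5-dichlorophenyl on the carbonyl carbon truly compare in this assay.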